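Pyrazole amides on a shared core: one step to come

The source may report more compounds than this note shows. Statements on the series, on what has been measured and on what is new or still open speak of the compounds shown alone.

Measured so far:
- compound 1 `CC1(C)Cc2c(sc(NC(=O)C3(CO)CC3)c2C(N)=O)C(C)(C)O1` — 1320 nM
- compound 2 `CC1(C)Cc2c(sc(NC(=O)c3[nH]ncc3Cl)c2C(N)=O)C(C)(C)O1` — 81 nM

The read-out is an assay on cells for positive allosteric modulation of Cystic fibrosis transmembrane conductance regulator variant G551D (Homo sapiens), with stated times of 10 min and 2 min, in the presence of a further agent that is not named here; on this read-out higher numbers stand for an effect only at larger amounts of compound and lower numbers for an effect already at smaller amounts. Within the data shown here, compound 1 gives the highest of the two numbers, and its only neighbour is compound 2, reached by a 16-fold lower number from compound 1 to compound 2 (1.21 log units; beyond the scatter). Among the measured compounds shown here, that single step exchanges the group on the carbonyl carbon of the amide, and it is the one comparison that bears on the next compound.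

Compound 3 `Cc1cc(C(=O)Nc2sc3c(c2C(N)=O)CC(C)(C)OC3(C)C)[nH]n1` is not yet measured. It differs from compound 1 as follows: 3-methyl-1H-pyrazol-5-yl in place of 1-(hydroxymethyl)cyclopropyl on a carbonyl carbon. For the measured compounds named here, the group entering is again a five-membered aromatic ring with two nitrogens on the carbonyl carbon, like the one entering in compound 2, though with a methyl instead of a chlorine and without an exact precedent for that substitution.

Given the size of a 16-fold lower number from compound 1 to compound 2 (1.21 log units; beyond the scatter), a large downward step is expected here too, taken as an 8.8-fold lower number from compound 1 to compound 3 (0.94 log units; beyond the scatter), and somewhat smaller than the chlorine case to allow for the untested methyl. Compound 3 is therefore estimated at 150 nM, with a range from 50 nM to 500 nM.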

Compound 3, half-maximal effective concentration: 590 nM
Compound 3: the middle estimate sits 3.9-fold (0.59 log units) below what was measured; the measured number lies above the stated range.
By their numbers in this assay, from the lowest: compound 2; then compound 3; then compound 1.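

In this assay, a five-membered aromatic ring with 2 hetero atoms on the carbonyl carbon does not by itself bring a large gain over 1-(hydroxymethyl)cyclopropyl: 3-methyl-1H-pyrazol-5-yl in that place gives only a 2.2-fold lower number from compound 1 to compound 3 (0.35 log units; beyond the scatter). The two aromatic groups are not interchangeable at this position, even though each has 6 heavy atoms and the same ring type, since the change between them gives a 7.3-fold higher number from compound 2 to compound 3 (0.86 log units; beyond the scatter). No accompanying measurement bears on the origin of this gap.

The chlorine-bearing group of compound 2 differs from the 3-methyl-1H-pyrazol-5-yl of compound 3 both in the atom it carries and in how its ring is arranged on the carbonyl carbon, so these compounds do not separate the contribution of either feature. On these data alone, it remains open how an unsubstituted pyrazole, or a pyrazole carrying bromine, an amine or a longer chain, would stand on this carbonyl carbon relative to compound 2 and compound 3.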